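The compounds below may be only part of what the source reports. "The series", "measured", "known", "first", "only" and "open" are said of these compounds alone.

Compound 1 `C=C(C)C(=O)Nc1cccc(-c2nc3ccccc3s2)c1` in an ADME assay on BJ cells (Homo sapiens) for inhibition, with a stated time of 72 h (a higher number here means that more compound is needed for the effect, a lower number that less compound is needed), gives > 25000 nM, which is a limit of the assay rather than a number.
Compound 2 `O=C(CCl)Nc1cccc(-c2nc3ccccc3s2)c1` in this assay gives 8500 nM.
Compound 3 `O=C(Nc1cccc(-c2nc3ccccc3s2)c1)c1cnccc1Cl` in this assay gives > 25000 nM, again a limit of the assay.

Compound 3 thus stands at the top of what the assay can read, a position shared by the limit of > 25000 nM in this assay, at which 2 of the 3 values shown sit. Compound 4 `O=C(Nc1cccc(-c2nc3ccccc3s2)c1)c1ccnc(Cl)c1` differs from it only in the group on the carbonyl carbon: 2-chloropyridin-4-yl in place of 4-chloropyridin-3-yl on a carbonyl carbon. The measured steps that reach compound 3 are an at least 2.9-fold higher number from compound 2 to compound 3 (0.46 log units; beyond the scatter) and a step that the two limits leave unreadable from compound 1 to compound 3, and neither swaps one chloropyridinyl group for another, so they give no direct guide. With the same atoms simply rearranged, no step beyond the scatter is expected in this assay; compound 4 is estimated to remain at a limit, 30000 nM (12000 nM to 80000 nM), implying a step that the limit leaves unreadable from compound 3 to compound 4 as the expected step.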

Compound 4, half-maximal effective concentration: > 25000 nM
Compound 4 was reported as a limit (the forecaster's own chance of this, stated with the estimate: 70%); the middle value does not contradict the limit.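

In this assay compound 4 gives > 25000 nM, a limit of the assay, so a second chloropyridinyl group on the carbonyl carbon ends at that limit. Replacing chloromethyl gives an at least 2.9-fold higher number from compound 2 to compound 4 (0.46 log units; beyond the scatter), while the steps to compound 4 from compound 1 and compound 3 cannot be read. Compound 2 alone gives a readable number at this position, and the other compounds share one limit: the limit of > 25000 nM in this assay, at which 3 of the 4 values shown sit.

As far as these compounds go, the true values of compound 3 and compound 4 stay unknown, so the two cannot be ordered. From the compounds shown here alone, whether a longer chloroalkyl chain or an amine on the carbonyl carbon would give a readable number also stays open.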